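This account rests on a few compounds, and the source may have more. Where it says the series, first, only, none or still open, it means among the compounds named here.

Among the measured compounds shown here, in an ADME assay on DU-145 cells (Homo sapiens) for cytotoxicity, read by MTT assay, with a stated time of 72 h (a higher number here means a weaker inhibitor, a lower number a stronger inhibitor), compound 1, whose structure is `COCOc1cc(C2=C(c3cc(OC)c(OC)c(OC)c3)C(=O)CC2O[SiH2]C(C)(C)C)ccc1OC`, gives 34 ug/mL, and this is the only number the set holds. Compound 2, drawn as `C=CCOc1cc(C2=C(c3cc(OC)c(OC)c(OC)c3)C(=O)C(O)C2)ccc1OC`, reaches only the limit of the assay with > 100 ug/mL. Compound 3, drawn as `COc1ccc(C2=C(c3cc(OC)c(OC)c(OC)c3)C(=O)C(OC(C)=O)C2)cc1`, likewise stops at the limit with > 100 ug/mL. So compound 1 stands alone with a numeric reading, while the other two sit at the limit of > 100 ug/mL in this assay, at which 2 of the 3 values shown sit.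

Compound 4, with the structure `COc1cc(C2=C(c3cc(C)c(OC)c(C)c3)C(O[SiH2]C(C)(C)C)CC2=O)cc(OC)c1OC`, has not been measured. Relative to compound 1 it carries the difference (4-methoxy-3,5-dimethylphenyl in place of 4-methoxy-3-(methoxymethoxy)phenyl on a double-bonded ring carbon); the two aryl groups share the shared core of compound 1, and the 4-methoxy-3,5-dimethylphenyl takes the place held by the 4-methoxy-3-(methoxymethoxy)phenyl.

No single-change step between measured compounds is shown, so there is nothing to scale the expectation against. Given that compound 1 gives 34 ug/mL, the step is expected to stay within the scatter or drift slightly toward weaker inhibition, with an estimated change of a 1.2-fold higher number from compound 1 to compound 4 (0.07 log units; within the scatter). For compound 4 the expected value in this assay is 40 ug/mL, between 10 ug/mL and 100 ug/mL.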

Compound 4, half-maximal inhibitory concentration: > 100 ug/mL
Compound 4 was reported as a limit; the forecaster's own chance of this, stated with the estimate: 30%; middle value at least 2.5-fold (0.39 log units) away from the limit.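

In this assay, among the compounds shown here, the replacement of 4-methoxy-3-(methoxymethoxy)phenyl by 4-methoxy-3,5-dimethylphenyl on a double-bonded ring carbon is the first change in a single place that can be read in this set, and it gives an at least 2.9-fold higher number from compound 1 to compound 4 (0.46 log units; beyond the scatter). For compound 4, the reading of > 100 ug/mL is a limit of the assay and not a number. The step therefore shows that the numeric reading at this position does not survive this exchange of aryl groups, although its full size stays unknown and compound 1 remains the only compound with a number: the limit of > 100 ug/mL in this assay, at which 3 of the 4 values shown sit.

The compounds shown cannot separate the departure of the methoxymethoxy group from the arrival of the two methyl groups, as both happen in the same step. As far as these compounds go, it also remains open how this position would read in this assay with a phenyl group carrying a hydroxyl group or an amine on the same double-bonded ring carbon, with the rest of compound 1 unchanged.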